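Pyridazinyl piperazine ureas: removing the methoxy

This account rests on a few compounds, and the source may have more. Where it says the series, first, only, none or still open, it means among the compounds named here.

Compound 3 `COc1ccc(N2CCN(C(=O)Nc3nc4ccc(F)cc4s3)CC2)nn1` sits at the limit in an assay on HEK293 cells for inhibition of transient receptor potential cation channel subfamily V member 1 (Homo sapiens), read by FLIPR; on this read-out lower numbers stand for stronger inhibition and higher numbers for weaker inhibition: compound 3 gives > 10000 nM, a limit of the assay and not a number. Compound 1 `O=C(Nc1nc2ccc(F)cc2s1)N1CCN(c2ccc(Cl)nn2)CC1` gives > 10000 nM, again a limit. Compound 2 `Cc1ccc(N2CCN(C(=O)Nc3ccc(OC(F)(F)F)cc3)CC2)nn1` gives > 10000 nM, also a limit. Among the measured compounds shown here, the one single-point step in the set, a step that the two limits leave unreadable from compound 1 to compound 3, is therefore unreadable, and all three values sit at the same limit (the limit of > 10000 nM in this assay, at which 3 of the 3 values shown sit). Compound 4 `O=C(Nc1nc2ccc(F)cc2s1)N1CCN(c2cccnn2)CC1` differs from compound 3 by hydrogen in place of methoxy on an aromatic carbon. For the measured compounds named here, no measured step bears on this change, and no step has produced a readable number in this assay. Compound 4 is accordingly expected to stay near the limit, with a step that the limit leaves unreadable from compound 3 to compound 4 as the estimated step, most likely within the scatter. The estimated value for compound 4 is 15000 nM, in the range 3000 nM to 60000 nM.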

Compound 4, half-maximal inhibitory concentration: > 10000 nM
Compound 4 ended at the assay's limit; the forecaster's own chance of this, stated with the estimate: 75%; the middle value is on the limit's open side.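

Compound 4 gives only a limit, as do compound 1 and compound 3, so no step among these three can be read: the limit of > 10000 nM in this assay, at which 4 of the 4 values shown sit.

The compounds shown leave open whether any change to the shared core gives a readable value.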